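Dimethylamino in place of methyl: notes on compound 4

A few compounds are considered here, and "the series" means these few. Any claim that something is new, unique, unknown or untested is made for them only; others in the source may bear on it.

Measured in a functional assay on MCF7 cells (Homo sapiens) for inhibition, read by CCK-8 assay, with a stated time of 48 h; on this read-out lower numbers stand for stronger inhibition and higher numbers for weaker inhibition:
- compound 1 `COc1cc(-c2cc3nccc(-c4c[nH]c5ccccc45)n3n2)cc(OC)c1OC`: > 10000 nM (a limit)
- compound 2 `COc1cc(-c2ccnc3cc(-c4ccc(C)cc4)nn23)cc(OC)c1OC`: 47 nM
- compound 3 `COc1cc(-c2ccnc3cc(-c4ccc(C(F)(F)F)cc4)nn23)cc(OC)c1OC`: 2440 nM

Of the two true numbers in this assay, compound 2 holds the lower, at 47 nM. The next compound, compound 4 `COc1cc(-c2ccnc3cc(-c4ccc(N(C)C)cc4)nn23)cc(OC)c1OC`, differs from it as follows: dimethylamino in place of methyl on an aromatic carbon. This places dimethylamino in place of methyl on an aromatic carbon, para to a large group. Among the compounds with values here, one measured step bears on this change: a 52-fold higher number from compound 2 to compound 3 (1.72 log units; beyond the scatter), a large step beyond the scatter, with trifluoromethyl in place of methyl. A single step is thin support, so a smaller move in the same direction is expected. The expected step is a 5.3-fold higher number from compound 2 to compound 4 (0.73 log units; beyond the scatter). For compound 4 the estimated value is 250 nM, with an expected range from 40 nM to 2500 nM.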

Compound 4, half-maximal inhibitory concentration: 44 nM
Beside the measured number, compound 4's estimate is 5.7-fold (0.75 log units) above it; the range from low to high includes it.
By their numbers in this assay, from the lowest: compounds 4 and 2 (each within the scatter of the next); then compound 3. At a limit, above all of these: compound 1.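

In this assay, the aromatic carbon para to a large group accepts dimethylamino in place of methyl with no change beyond the scatter: a 1.1-fold lower number from compound 2 to compound 4 (0.03 log units; within the scatter). The large loss with trifluoromethyl therefore does not extend to every replacement of methyl at this position, as dimethylamino in its place gives a 55-fold lower number from compound 3 to compound 4 (1.74 log units; beyond the scatter). No measurement shown gives a cause for this result.

On these data alone, with only these groups at this position, what separates dimethylamino from trifluoromethyl stays open. As far as these compounds go, how a primary amine or a carboxylic acid on this carbon would read remains unknown.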